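The source may report more compounds than this note shows. Statements on the series, on what has been measured and on what is new or still open speak of the compounds shown alone.

Among the measured compounds shown here, in a functional assay on HT-29 cells (Homo sapiens) for cytotoxicity (on this read-out lower numbers stand for stronger inhibition and higher numbers for weaker inhibition), compound 1 `COc1ccc(S(=O)(=O)N2CCc3cccc(NC(=O)c4ccc(F)cc4)c32)cc1` gives 55 nM and compound 2 `COc1ccc(S(=O)(=O)N2CCc3cccc(NC(=O)c4ccncc4)c32)cc1` gives 8.6 nM, so compound 2 holds the lower of the two numbers so far. Compound 3 `COc1ccc(S(=O)(=O)N2CCc3cccc(NC(C)=O)c32)cc1` keeps the shared core and differs from compound 2 at one place: methyl in place of pyridin-4-yl on a carbonyl carbon. For the measured compounds named here, only one measured step bears on this: a 6.4-fold lower number from compound 1 to compound 2 (0.81 log units; beyond the scatter). That step exchanges one ring for another on the same carbonyl carbon and is beyond the scatter. Going by the values given here, compound 3 has no ring there, and no measured compound shows that change, so the guidance is indirect. A larger step than the measured one is expected, towards a higher number in this assay. The expected step is a 23-fold higher number from compound 2 to compound 3 (1.37 log units; beyond the scatter). Compound 3 is estimated at 200 nM, within a range of 40 nM to 1500 nM.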

Compound 3, half-maximal inhibitory concentration: 51 nM
Estimate against measurement, compound 3: 3.9-fold (0.59 log units) above, within the range that was stated.
By their numbers in this assay, from the lowest: compound 2; then compounds 3 and 1 (each within the scatter of the next).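

In this assay, a ring on the carbonyl carbon does not by itself set the number, since methyl, which brings no ring, reads the same as 4-fluorophenyl within the scatter (a 1.1-fold lower number from compound 1 to compound 3 (0.03 log units; within the scatter)). Pyridin-4-yl stands apart from methyl as well as from 4-fluorophenyl (a 5.9-fold higher number from compound 2 to compound 3 (0.77 log units; beyond the scatter)), so the lower number of compound 2 belongs to that particular ring, not to any ring at this place. Nothing at hand accounts for the difference between pyridin-4-yl and the other two groups.

As far as these compounds go, whether an unsubstituted phenyl, a piperidine ring or a longer chain such as butyl on the same carbonyl carbon would read with compound 2 or with compound 1 and compound 3 remains open. Also open, from the compounds shown here alone, is whether the ring nitrogen of pyridin-4-yl matters, or the ring as a whole.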